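This account rests on a few compounds, and the source may have more. Where it says the series, first, only, none or still open, it means among the compounds named here.

Series notes. Values in an assay on HEK293 cells for antagonist activity at transient receptor potential cation channel subfamily V member 2 (Rattus norvegicus), read by fluorescence and calcium flux, with a stated time of 5 min (a higher number here means a weaker inhibitor, a lower number a stronger inhibitor), so far:

Compound 1 `CCCCCCCCCCCCCCCC[Se]CCC(=O)NCc1ccc(O)c(OC)c1`: 4300 nM
Compound 2 `CCCCCCCCCCCCCCCC[Se]C[C@H](N)C(=O)NCc1ccc(O)c(OC)c1`: 1200 nM
Compound 3 `CCCCCCCCCCCCCCCCOC(=O)CSC[C@H](N)C(=O)NCc1ccc(O)c(OC)c1`: 1400 nM

Compound 2 and compound 1 differ in one place, (hydrogen in place of amino on a saturated chain carbon bound to a carbonyl carbon and a saturated chain carbon), and that change gave a 3.6-fold higher number from compound 2 to compound 1 (0.55 log units; beyond the scatter). Compound 3 carries a different core from compound 2; the difference between the two cores is not broken down here, and their two values lie within the usual scatter of each other.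

Compound 4 `CCCCCCCCCCCCCCCCOC(=O)CSCCC(=O)NCc1ccc(O)c(OC)c1` is still to be measured in this assay. It stands to compound 3 as compound 1 stands to compound 2: the same change, (hydrogen in place of amino on a saturated chain carbon bound to a carbonyl carbon and a saturated chain carbon), at the same place. The expected step is about as large as the earlier one, a 3.2-fold higher number from compound 3 to compound 4 (0.51 log units; beyond the scatter). This rests on compound 2 and compound 1 giving a 3.6-fold higher number from compound 2 to compound 1 (0.55 log units; beyond the scatter), with compound 3 starting near compound 2. For compound 4 the estimate is 4500 nM, expected to fall between 2000 nM and 10000 nM.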

Compound 4, half-maximal inhibitory concentration: > 10000 nM
Compound 4: no number, only a limit (the forecaster's own chance of this, stated with the estimate: 10%); middle value at least 2.2-fold (0.34 log units) away from the limit.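

Replacing amino with hydrogen on a saturated chain carbon bound to a carbonyl carbon and a saturated chain carbon again gives a weaker inhibitor in this assay, with an at least 7.1-fold higher number from compound 3 to compound 4 (0.85 log units; beyond the scatter) on the core of compound 3. Compound 4 gives > 10000 nM, which is a limit of the assay and not a number. The direction of the change therefore carries over between the two cores, but its size on the second core has only a lower bound, and no difference in size can be shown or excluded: the same change on two cores in this assay, a 3.6-fold higher number (0.55 log units; beyond the scatter) from compound 2 to compound 1 and an at least 7.1-fold higher number (0.85 log units; beyond the scatter) from compound 3 to compound 4; the limit leaves it open whether they differ.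

On these data alone, whether a methylamine, a hydroxyl or a carboxylic acid at this place would retain the activity remains open. So does the size of this change on a core with a shorter chain.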